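This account rests on a few compounds, and the source may have more. Where it says the series, first, only, none or still open, it means among the compounds named here.

Compound 3 `O=S(=O)(c1cccc(F)c1)c1cnc2cc(F)ccc2c1-c1cccc(F)c1` shows the lowest number of the three compounds measured in an ADME assay on microsomes from liver (Homo sapiens) for metabolic stability, tested at 2.5 uM; a lower number here means slower removal, a higher number faster removal of the compound: compound 3 gives 0.24 mL/min, whereas compound 1 `COc1cccc(S(=O)(=O)c2cnc3cc(F)ccc3c2-c2cccc(F)c2)c1` gives 3.36 mL/min and compound 2 `Cc1ccc(S(=O)(=O)c2cnc3cc(F)ccc3c2-c2cccc(Cl)c2)cc1C` gives 4.01 mL/min. The only single-point step among these compounds runs a 14-fold lower number from compound 1 to compound 3 (1.15 log units; beyond the scatter), a change on the aryl ring of the sulfonyl group. Compound 4 `Cc1ccc(S(=O)(=O)c2cnc3cc(F)ccc3c2-c2cccc(F)c2)cc1C` is the next compound, differing from compound 3 as follows: 3,4-dimethylphenyl in place of 3-fluorophenyl on a sulfonyl sulfur. Among the compounds with values here, no measured step covers exactly this exchange, so the one measured step on the sulfonyl aryl ring is the nearest guide; it shows that a change at this ring can move this assay by a large amount. Compound 2, which carries the same 3,4-dimethylphenyl on the sulfonyl sulfur, sits well above compound 3 in this assay. Compound 4 is therefore expected to move upward from compound 3 by about a 13-fold higher number from compound 3 to compound 4 (1.10 log units; beyond the scatter) in this assay. The estimate for compound 4 is 3 mL/min, with a range from 1.2 mL/min to 7 mL/min.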

Compound 4, intrinsic clearance in a liver preparation (reported as CLH), per the amount of preparation that the assay uses: 3.71 mL/min
Beside the measured number, compound 4's estimate is 1.2-fold (0.09 log units) below it; low and high end bracket the measured number.
By their numbers in this assay, from the lowest: compound 3; then compounds 1, 4 and 2 (each within the scatter of the next).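

In this assay the exchange to 3,4-dimethylphenyl in place of 3-fluorophenyl on a sulfonyl sulfur now has its own direct measure, a change of a 15-fold higher number from compound 3 to compound 4 (1.19 log units; beyond the scatter) and so a large one. Within the data shown here, the 3,4-dimethylphenyl and 3-methoxyphenyl groups on that sulfur do not separate, with a 1.1-fold higher number from compound 1 to compound 4 (0.04 log units; within the scatter) and thus no real change, which leaves 3-fluorophenyl as the one group of these three with a low number. With 3,4-dimethylphenyl held on the sulfur, fluoro in place of chloro on an aromatic carbon gives a 1.1-fold lower number from compound 2 to compound 4 (0.03 log units; within the scatter) and likewise no real change.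

Nothing shown gives a reason for the low number of compound 3. Whether that low number is specific to 3-fluorophenyl stays open, since no other ring on the sulfur is shown, such as a 4-fluorophenyl or a phenyl carrying an amine or a carboxylic acid.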